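Working notes: propyl in place of methylsulfanyl, compound 4

This account rests on a few compounds, and the source may have more. Where it says the series, first, only, none or still open, it means among the compounds named here.

Measured so far in a functional assay (spleen, spleen) for activation, with Mus musculus as the target; on this read-out lower numbers stand for an effect already at smaller amounts and higher numbers for an effect only at larger amounts of compound:
compound 1, `COc1ccc(Cn2c(O)nc3c(N)ncnc32)cc1`, gives 10 uM
compound 2, `CSc1nc(N)c2nc(O)n(Cc3ccccc3)c2n1`, gives 0.1 uM
compound 3, `Nc1ncnc2c1nc(O)n2Cc1ccc(F)cc1`, gives 10 uM

Compound 2 stands lowest of the three numbers in this assay; compound 1 and compound 3 both sit well above it, a gap beyond the scatter, while the step of no change at the digits printed from compound 1 to compound 3 (within the scatter) shows that fluoro in place of methoxy on the benzyl ring does nothing beyond the scatter.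

Compound 4, `CCCc1nc(N)c2nc(O)n(Cc3ccccc3)c2n1`, differs from compound 2 at a single place: propyl in place of methylsulfanyl on an aromatic carbon. Going by the values given here, no measured step touches this position; the only step in hand, from compound 1 to compound 3, concerns the other aromatic ring and so does not bear on it. The data therefore give no direct guide to either direction or size. As a working expectation, a modest move away from the low number of compound 2 seems as likely as none, so a step of a 3.0-fold higher number from compound 2 to compound 4 (0.48 log units; beyond the scatter) in this assay is estimated, with wide uncertainty. Compound 4 is expected at 0.3 uM, within a range from 0.05 uM to 3 uM.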

Compound 4, minimum effective concentration: 1 uM
For compound 4 the middle estimate is 3.3-fold (0.52 log units) below the measured one, and the stated range covers the measured number.
By their numbers in this assay, from the lowest: compound 2; then compound 4; then compounds 1 and 3 (each within the scatter of the next).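

In this assay, the group on the aromatic carbon between two ring nitrogen atoms proves sensitive to change: propyl in place of methylsulfanyl gives a 10-fold higher number from compound 2 to compound 4 (1.00 log units; beyond the scatter), whereas fluoro in place of methoxy gave no change at the digits printed from compound 1 to compound 3 (within the scatter) at its own place. The change at this position removes the sulfur and the one hydrogen-bond acceptor counted for methylsulfanyl and also raises the heavy-atom count, so these differences cannot be separated within this single pair. Nothing at hand accounts for the higher number with propyl.

Still open, from the compounds shown here alone, is whether the sulfur or the chain itself matters, and an ethylsulfanyl or a methoxy group at this place would bear on that question. An amine or a butyl chain there would show how far the position tolerates other groups.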